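Amide-to-carboxy step on the shared core

The source may report more compounds than this note shows. Statements on the series, on what has been measured and on what is new or still open speak of the compounds shown alone.

The three measured compounds share one core and differ in the aryl group and in the amide substituent: compound 1 `C=CC1=C(C(=O)NCc2ccc(Cl)cc2)C(c2ccc(OC)cc2)OC1`, compound 2 `C=CC1=C(C(=O)NCCC)C(c2ccc(OC)c(OC)c2)OC1` and compound 3 `C=CC1=C(C(=O)Nc2ccc(C)cc2)C(c2ccc(F)cc2)OC1`. In a functional assay on SW480 cells (Homo sapiens) for cytotoxicity, read by MTT assay, with a stated time of 24 h (on this read-out lower numbers stand for stronger inhibition and higher numbers for weaker inhibition), compound 1 gives > 100000 nM, which is a limit of the assay and not a number. In this assay compound 2 gives > 100000 nM, again a limit. In this assay compound 3 gives > 100000 nM, also a limit. Going by the values given here, compound 2 therefore stands where every measured compound stands, at the limit of > 100000 nM in this assay, at which 3 of the 3 values shown sit; no step between measured compounds can be sized, and no compound can be ranked against another.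

Compound 4 `C=CC1=C(C(=O)O)C(c2ccc(OC)c(OC)c2)OC1` is still to be measured. It differs from compound 2 in one place: hydroxy in place of propylamino on a carbonyl carbon. Cut one bond further out, the change reads propylcarbamoyl to carboxy.

Among the compounds with values here, with no measured step to lean on and compound 2 sitting at the limit, the step from compound 2 to compound 4 is expected to be none beyond the scatter, a step that the limit leaves unreadable from compound 2 to compound 4. For compound 4 the estimate in this assay is 150000 nM, expected between 50000 nM and 500000 nM, with a reading reported only as a limit the most probable outcome.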

Compound 4, half-maximal inhibitory concentration: > 100000 nM
Compound 4: no number, only a limit; the forecaster's own chance of this, stated with the estimate: 85%; the middle value lies beyond the limit too.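

In this assay compound 4 gives > 100000 nM, a limit of the assay and not a number. Going by these compounds alone, compound 2 also stands at a limit, and no step from compound 2 to compound 4 can be read. The compounds shown leave open whether any change on the shared core yields a measurable value in this assay.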